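Moving a Carbon Within the Side Chain of Compound 2

A few compounds are considered here, and "the series" means these few. Any claim that something is new, unique, unknown or untested is made for them only; others in the source may bear on it.

Within the data shown here, in a functional assay on the whole organism with Mus musculus as the target (on this read-out lower numbers stand for an effect already at smaller amounts and higher numbers for an effect only at larger amounts of compound), compound 2 `CNC(=O)[C@@H](C)NCc1ccc(OCc2ccccc2)cc1` gives 40.5 mg/kg, the lowest of the three numbers measured so far. Compound 1 `CN(CC(N)=O)Cc1ccc(OCc2cccc(Cl)c2)cc1` gives 114 mg/kg, and compound 3 `CNC(=O)[C@@H](CC(C)C)NCc1ccc(OCc2ccccc2)cc1` gives 192 mg/kg.

The open question is compound 4 `CC[C@@H](NCc1ccc(OCc2ccccc2)cc1)C(N)=O`, which has the same atoms as compound 2, joined differently: 1-carbamoylpropyl in place of 1-(methylcarbamoyl)ethyl on an amine nitrogen. Among the measured compounds shown here, only one measured step offers any guide, and it is indirect. Placing isopropyl in place of hydrogen on a saturated chain carbon gave a 4.7-fold higher number from compound 2 to compound 3 (0.68 log units; beyond the scatter), a modest rise. That change adds atoms, whereas compound 4 adds none, so only a small part of that rise seems likely to carry over. In this assay the expected step is a 1.5-fold higher number from compound 2 to compound 4 (0.17 log units; within the scatter), a slight upward move that would stay within the scatter. The estimate for compound 4 is 60 mg/kg, with an expected range of 25 mg/kg to 140 mg/kg.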

Compound 4, dose for half-maximal effect: 55 mg/kg
Compound 4: the middle estimate sits 1.1-fold (0.04 log units) above what was measured, within the range that was stated.
By their numbers in this assay, from the lowest: compounds 2 and 4 (each within the scatter of the next); then compounds 1 and 3 (each within the scatter of the next).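

In this assay, putting 1-carbamoylpropyl in place of 1-(methylcarbamoyl)ethyl on the amine nitrogen gives a 1.4-fold higher number from compound 2 to compound 4 (0.13 log units; within the scatter), so the two numbers cannot be told apart. Among these compounds, the only earlier step at this side chain added atoms and gave a 4.7-fold higher number from compound 2 to compound 3 (0.68 log units; beyond the scatter), whereas this one shows that the same atoms can be joined differently without a change beyond the scatter. No measurement at hand explains why these two side chains read alike.

Going by these compounds, what remains open is how far this holds for other side chains on the same amine nitrogen, such as a longer chain in place of 1-carbamoylpropyl. It is also unknown how a carboxylic acid in place of the carbamoyl group would read in this whole-animal test.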